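Will compound 3 stay level with compound 2?

A few compounds are considered here, and "the series" means these few. Any claim that something is new, unique, unknown or untested is made for them only; others in the source may bear on it.

In a functional assay, read by spectrophotometry (on this read-out lower numbers stand for an effect already at smaller amounts and higher numbers for an effect only at larger amounts of compound), compound 2 (`COc1ccc(-c2cc(=O)c3ccc(OCCCCCN4CCC(CCO)CC4)cc3o2)cc1`) gives 27.9 nM and compound 1 (`COc1ccc(-c2cc(=O)c3ccc(OCCCCN4CCC(C)CC4)cc3o2)cc1`) gives 28.1 nM as its value, so the two stand level, within the scatter of each other.

Next comes compound 3 (`COc1ccc(-c2cc(=O)c3ccc(OCCCCCCN4CCC(C)CC4)cc3o2)cc1`), which has not yet been measured. The difference from compound 2 is (4-methylpiperidin-1-yl)methyl in place of 4-(2-hydroxyethyl)piperidin-1-yl on a saturated chain carbon, five bonds along the chain from an oxygen on an aromatic ring and amounts to (4-methylpiperidin-1-yl)methyl in place of 4-(2-hydroxyethyl)piperidin-1-yl on a saturated chain carbon, five bonds along the chain from an oxygen on an aromatic ring. Cut one bond further out, it reads (4-(2-hydroxyethyl)piperidin-1-yl)methyl to 2-(4-methylpiperidin-1-yl)ethyl.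

Among the compounds with values here, only one measured step bears on this. It is a 1.0-fold lower number from compound 1 to compound 2 (0.00 log units; within the scatter) and it put (4-(2-hydroxyethyl)piperidin-1-yl)methyl in place of 4-methylpiperidin-1-yl on a saturated chain carbon, four bonds along the chain from an oxygen on an aromatic ring. A similar exchange of end groups made no difference there, but one pair is thin evidence, so the range stays wide.

The step expected in this assay is a 1.1-fold higher number from compound 2 to compound 3 (0.03 log units; within the scatter) and is not expected to go beyond the scatter. Compound 3 is estimated at 30 nM with an expected range from 10 nM to 90 nM for this measurement.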

Compound 3, half-maximal effective concentration: 32.6 nM
The estimate for compound 3 lay 1.1-fold (0.04 log units) below the measured number, and the stated range covers the measured number.
By their numbers in this assay, from the lowest: compounds 2, 1 and 3 (each within the scatter of the next).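

Within the data shown here, compound 3 adds the first comparison in which the end group stays the same and only the chain changes: in this assay, the exchange gives a 1.2-fold higher number from compound 1 to compound 3 (0.06 log units; within the scatter), with 2-(4-methylpiperidin-1-yl)ethyl in place of 4-methylpiperidin-1-yl, so this longer chain is tolerated with the 4-methylpiperidin-1-yl end in place. The other new step, a 1.2-fold higher number from compound 2 to compound 3 (0.07 log units; within the scatter), replaces the 4-(2-hydroxyethyl)piperidin-1-yl-bearing end with one that has no hydrogen-bond donor, and this change also leaves the number within the scatter. Across these three compounds, then, no change at this position has yet moved the result beyond the scatter, and nothing available accounts for this flat picture.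

The compounds shown do not tell whether a morpholine or a piperazine at the end of the chain would stay level with the piperidines, or whether a carboxylic acid in place of the amine would do so. They also leave open how far the tolerance runs, since a much shorter or much longer chain could still shift the number beyond the scatter.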